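The compounds below may be only part of what the source reports. "The series", "measured", "known", "first", "only" and "open" are said of these compounds alone.

In an ADME assay on HEK-293T cells (Homo sapiens) for cytotoxicity, read by CCK-8 assay, with a stated time of 48 h (on this read-out higher numbers stand for lower toxicity in this test and lower numbers for higher toxicity in this test), compound 1 `O=C(CNc1nc(N2CCc3ccccc3C2)nc2ccccc12)Nc1ccccc1` gives 36600 nM and compound 3 `O=C(CNc1nc(N2CCCC2)nc2ccccc12)Nc1ccccc1` gives 23300 nM, two values within the scatter of each other. For compound 2 `CCN(CC)c1nc(NCC(=O)NCc2ccccc2)c2ccccc2n1` the result is only a limit, > 100000 nM. Compound 4 `O=C(CNc1nc(N2CCCC2)nc2ccccc12)Nc1cc(Cl)cc(Cl)c1` differs from compound 3 as follows: 3,5-dichlorophenyl in place of phenyl on an amide-type nitrogen. In words, 3,5-dichlorophenyl stands in place of phenyl on an amide-type nitrogen. For the measured compounds named here, the only measured step, a 1.6-fold lower number from compound 1 to compound 3 (0.20 log units; within the scatter), lies within the scatter and was made on an aromatic carbon, so it does not touch this nitrogen and offers only weak guidance. A modest move towards a lower number is therefore expected in this assay, an estimated 1.7-fold lower number from compound 3 to compound 4 (0.22 log units; within the scatter). For compound 4 the expected value is 14000 nM, within an estimated range from 4000 nM to 45000 nM.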

Compound 4, half-maximal cytotoxic concentration: 15900 nM
Compound 4: middle estimate off by 1.1-fold (0.06 log units), on the low side, within the range that was stated.
By their numbers in this assay, from the lowest: compounds 4, 3 and 1 (each within the scatter of the next, the first and the last beyond it). At a limit, above all of these: compound 2.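

At the amide-type nitrogen, 3,5-dichlorophenyl in place of phenyl gives a 1.5-fold lower number from compound 3 to compound 4 (0.17 log units; within the scatter) in this assay. For the compounds shown here, the earlier compounds showed a step only on an aromatic carbon, so this is the first sign that a change on this nitrogen, here the addition of two chlorine atoms to the phenyl, can also stay within the scatter. No measurement shown bears on the cause of this step. As far as these compounds go, it remains open whether an aliphatic amine or a carboxylic acid on this phenyl would shift the number beyond the scatter. From the compounds shown here alone, a longer chain between this nitrogen and the ring, as a benzyl group, also remains untested against compound 3.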